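The source may hold more compounds than are shown below. What is called first, only, known or untested is meant among the compounds shown, and "the series" means these compounds.

In a functional assay on G-361 cells (Homo sapiens) for antiproliferative activity, with a stated time of 72 h (a lower number here means a stronger inhibitor, a higher number a weaker inhibitor), compound 1 `OC[C@H]1O[C@@H](n2cnc3c(NCc4ccc(F)cc4)ncnc32)[C@H](O)[C@@H]1O` gives > 166000 nM as a limit and not a number. Compound 2 `OC[C@H]1O[C@@H](n2cnc3c(NCc4ccc(Cl)c(Cl)c4)ncnc32)[C@H](O)[C@@H]1O` gives 145000 nM in this assay and the step of an at least 1.1-fold lower number from compound 1 to compound 2 (0.05 log units; that floor lies within the scatter) stays within the scatter. Among the compounds with values here, compound 3 `OC[C@H]1O[C@@H](n2cnc3c(NCc4ccc(OC(F)(F)F)cc4)ncnc32)[C@H](O)[C@@H]1O` has trifluoromethoxy in place of fluoro on an aromatic carbon and that single measured step on the same aromatic ring is the only guide. No change beyond the scatter is therefore expected in this assay and the estimated step of an at least 1.1-fold lower number from compound 1 to compound 3 (0.07 log units; that floor lies within the scatter) reflects this. The expected value for compound 3 is 140000 nM with an estimated range of 65000 nM to 260000 nM and a limit instead of a number remains possible.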

Compound 3, half-maximal inhibitory concentration: > 166000 nM
Compound 3: a limit, no number; the forecaster's own chance of this, stated with the estimate: 45%; at least 1.1-fold (0.07 log units) between middle value and limit.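

No step can be read from compound 1 to compound 3, since both give only a limit in this assay: the limit of > 166000 nM in this assay, at which 2 of the 3 values shown sit. The compounds shown leave open whether trifluoromethoxy in place of fluoro changes the result in this assay at all.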